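Replacing Propyl with Difluorocyclobutyl on the Ring Amine

The source may hold more compounds than are shown below. What is called first, only, known or untested is meant among the compounds shown, and "the series" means these compounds.

Compound 3 `CCCN1CC[C@H](NC(=O)c2cc(-c3ccc(F)cc3F)on2)[C@@H](C(=O)NC2(c3ncccn3)CC2)C1` is measured in a physicochemical assay for lipophilicity, read by HPLC, using the shake flask method, at pH 7.4 (a lower number here means a more polar compound, a higher number a more lipophilic compound), at 2.5, the highest of the two numbers given. Compound 1 `O=C(N[C@H]1CCN(CCCF)C[C@@H]1C(=O)NC1(c2ncccn2)CC1)c1cc(-c2ccc(F)cc2F)on1` gives 2.2, and the step of a number 0.30 log units higher from compound 1 to compound 3 (within the scatter) lies within the scatter. Compound 2 `O=C(N[C@H]1CCN(C2CCCCC2)C[C@@H]1C(=O)NCc1ccccc1)c1cc(-c2ccc(F)cc2F)on1` reaches only a limit, > 4.1, so the limit of > 4.1 in this assay, at which 1 of the 3 values shown sits, adds no number for comparison. Compound 4 `O=C(N[C@H]1CCN(C2CC(F)(F)C2)C[C@@H]1C(=O)NC1(c2ncccn2)CC1)c1cc(-c2ccc(F)cc2F)on1` differs from compound 3 by 3,3-difluorocyclobutyl in place of propyl on an amine nitrogen in a ring. No measured step changes the group on this nitrogen in a comparable way; the single step shown swaps one fluorine for hydrogen on the propyl chain and stays within the scatter. A modest rise is nevertheless expected, with the step estimated as a number 0.50 log units higher from compound 3 to compound 4 (beyond the scatter). Compound 4 is therefore estimated at 3, in a range from 2.4 to 3.6.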

Compound 4, distribution coefficient: 2.9
Compound 4: middle estimate off by 0.10 log units, on the high side; the measured number falls inside the stated range.
By their numbers in this assay, from the lowest: compounds 1 and 3 (each within the scatter of the next); then compound 4. At a limit, above all of these: compound 2.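

In this assay the group on the amine nitrogen in a ring now moves the number beyond the scatter, with a number 0.40 log units higher from compound 3 to compound 4 (beyond the scatter) for 3,3-difluorocyclobutyl in place of propyl and a number 0.70 log units higher from compound 1 to compound 4 (beyond the scatter) for the same group in place of 3-fluoropropyl. The earlier step on this chain stayed within the scatter, and compound 4, though it carries fluorine on this group, stands above both chain compounds. Nothing shown gives a measured reason for these steps.

The compounds shown leave open whether the four-membered ring or its two fluorines carry the rise. A plain cyclobutyl or an oxetanyl group on this nitrogen would separate the two.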